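Pyrazolylamino series: hydroxy-methylpropyl pyrazole variant of compound 2

The source may hold more compounds than are shown below. What is called first, only, known or untested is meant among the compounds shown, and "the series" means these compounds.

Measured so far:
compound 1, `Cc1ccc(CNC(=O)c2cccc(C(C)Oc3cccnc3Nn3cnnc3)c2)cc1`, 23700 nM
compound 2, `Cc1ccc(CNC(=O)c2cccc(C(C)Oc3ccnc(Nc4cn(C)nc4C)c3)c2)cc1`, 13400 nM

In a functional assay on NCI-H3122 cells (Homo sapiens) for antiproliferative activity, read by MTT assay, with a stated time of 48 h (a lower number here means a stronger inhibitor, a higher number a weaker inhibitor), compound 1 gives 23700 nM and compound 2 gives 13400 nM; compound 2 has the lower of the two numbers, but the gap to compound 1 lies within the scatter, so the two cannot be ranked on these data. Compound 3, `Cc1ccc(CNC(=O)c2cccc(C(C)Oc3ccnc(Nc4cnn(CC(C)(C)O)c4)c3)c2)cc1`, differs from compound 2 in one place: 1-(2-hydroxy-2-methylpropyl)-1H-pyrazol-4-yl in place of 1,3-dimethyl-1H-pyrazol-4-yl on a nitrogen on an aromatic ring. Among the measured compounds shown here, no step of this kind between measured compounds is on record, so nothing here tells how the assay responds to it. The expectation for the step from compound 2 to compound 3 is a 1.1-fold lower number from compound 2 to compound 3 (0.05 log units; within the scatter), that is, no change beyond the scatter in either direction. Compound 3 is therefore estimated at 12000 nM in this assay, within a range from 4000 nM to 36000 nM, the width reflecting the absence of any comparable step.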

Compound 3, half-maximal inhibitory concentration: > 100000 nM
Compound 3: only a limit was reported; the forecaster's own chance of this, stated with the estimate: 10%; middle value at least 8.3-fold (0.92 log units) away from the limit.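

In this assay, among the compounds shown here, the group on this amino nitrogen is not a neutral choice: 1-(2-hydroxy-2-methylpropyl)-1H-pyrazol-4-yl in place of 1,3-dimethyl-1H-pyrazol-4-yl gives an at least 7.4-fold higher number from compound 2 to compound 3 (0.87 log units; beyond the scatter), the only step on record and one that lies beyond the scatter. Compound 3 gives > 100000 nM, which is a limit of the assay and not a number. The full size of the step therefore cannot be stated, and the reading rests on a single value at the limit: the limit of > 100000 nM in this assay, at which 1 of the 3 values shown sits.

Still open, as far as these compounds go, is whether this step goes with the hydroxy group itself or with the branched chain that carries it. A 2-methylpropyl chain without the hydroxy group on the pyrazole nitrogen, or a chain ending in an amine or a carboxylic acid, would help separate the two.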